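Lactam ring expansion and solubility across two cores

This account rests on a few compounds, and the source may have more. Where it says the series, first, only, none or still open, it means among the compounds named here.

Compound 1 `O=C1CCCN1c1cccc(C(=O)N(c2ncccc2Cl)[C@@H]2CCCNC2)c1` and compound 2 `O=C1CCCCN1c1cccc(C(=O)N(c2ncccc2Cl)[C@@H]2CCCNC2)c1` share one core. In a physicochemical assay for solubility, at pH 7.4 (on this read-out higher numbers stand for higher solubility and lower numbers for lower solubility), compound 1 gives 67000 nM. Compound 2 sits at > 973000 nM, which is a limit of the assay and not a number. The change is 2-oxopiperidin-1-yl in place of 2-oxopyrrolidin-1-yl on an aromatic carbon, and the step is an at least 14-fold higher number from compound 1 to compound 2 (1.16 log units; beyond the scatter). Compound 3 `O=C1CCCN1c1cnc(NCc2c(F)ccc3c2CCO3)n2cnnc12` has a different core; the difference between the two cores is not broken down here. In this assay compound 3 gives < 1600 nM, again a limit of the assay rather than a number. Compound 4 `O=C1CCCCN1c1cnc(NCc2c(F)ccc3c2CCO3)n2cnnc12`, not yet measured, carries the same kind of change, (2-oxopiperidin-1-yl in place of 2-oxopyrrolidin-1-yl on an aromatic carbon); the place now lies on a six-membered aromatic ring with 2 nitrogen, part of a fused or bridged system of two rings, ortho to a fused ring, two atoms from the ring nitrogen, meta to a fused ring and para to a large group, where in compound 1 it lay on a ring of carbon only, meta to a large group. Resting on the measured step of an at least 14-fold higher number from compound 1 to compound 2 (1.16 log units; beyond the scatter), the expected step is an at least 3.7-fold higher number from compound 3 to compound 4 (0.57 log units; beyond the scatter), although the starting value is only a limit. Compound 4 is therefore expected to give about 6000 nM, likely between 1000 nM and 40000 nM.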

Compound 4, solubility: 351000 nM
For compound 4 the middle estimate is 59-fold (1.77 log units) below the measured one, and the stated range ends below it.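

In this assay the change to 2-oxopiperidin-1-yl from 2-oxopyrrolidin-1-yl gives an at least 210-fold higher number from compound 3 to compound 4 (2.34 log units; beyond the scatter) and so runs the same way as an at least 14-fold higher number from compound 1 to compound 2 (1.16 log units; beyond the scatter) on the core of compound 1. Compound 3 stands at a limit of the assay, so the new step has no fixed size: the limit of < 1600 nM in this assay, at which 1 of the 4 values shown sits. Compound 2 also stands at a limit of the assay, so the two steps cannot be ranked by size: the limit of > 973000 nM in this assay, at which 1 of the 4 values shown sits.

As far as these compounds go, the shared direction rests on these two pairs only, and whether it holds on a third core stays open. Also open, from the compounds shown here alone, is how a 2-oxoazepan-1-yl or a 3-oxomorpholin-4-yl group in the same place would read on either core.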